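Halogenated biaryl ethers: cytotoxicity of a third analogue

The source may hold more compounds than are shown below. What is called first, only, known or untested is meant among the compounds shown, and "the series" means these compounds.

Compound 1 `Cc1cc(-c2ccccc2F)cc(C)c1Oc1cc(N)nc(Nc2ccc(C#N)cc2)n1`: 29300 nM
Compound 2 `Cc1cc(-c2ccc(F)cc2)cc(C)c1Oc1cc(N)nc(Nc2ccc(C#N)cc2)n1`: 23100 nM

Both values come from a toxicity assay on MT4 cells (Homo sapiens) for cytotoxicity, read by MTT assay; a lower number here means that less compound is tolerated, a higher number that more compound is tolerated. Among the measured compounds shown here, compound 2, at 23100 nM, cannot be separated from compound 1, the only other measured analogue, and the step of a 1.3-fold lower number from compound 1 to compound 2 (0.10 log units; within the scatter) gives no order between them. Next is compound 3 `Cc1cc(-c2ccccc2Cl)cc(C)c1Oc1cc(N)nc(Nc2ccc(C#N)cc2)n1`, with 2-chlorophenyl in place of 4-fluorophenyl on an aromatic carbon. For the measured compounds named here, the one measured step bearing on this change is that same swap of 4-fluorophenyl for 2-fluorophenyl, and it stayed within the scatter. Going by the values given here, no step from a fluorinated to a chlorinated ring has been measured, so the evidence is thin and the range is kept wide. No shift beyond the scatter is expected in this assay, and the estimated change is a 1.1-fold higher number from compound 2 to compound 3 (0.05 log units; within the scatter). For compound 3 the expected value is 26000 nM, with an estimated range of 13000 nM to 50000 nM.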

Compound 3, half-maximal cytotoxic concentration: 25100 nM
The estimate for compound 3 lay 1.0-fold (0.02 log units) above the measured number; the measured number falls inside the stated range.
By their numbers in this assay, from the lowest: compounds 2, 3 and 1 (each within the scatter of the next).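

In this assay the step of a 1.1-fold higher number from compound 2 to compound 3 (0.04 log units; within the scatter) changes both the halogen and its place on the ring, and it stays within the scatter. The more direct comparison, chloro in place of fluoro on an aromatic carbon, gives a 1.2-fold lower number from compound 1 to compound 3 (0.07 log units; within the scatter) and also stays within the scatter, so this first change of halogen gives compound 1, compound 2 and compound 3 no order. Nothing on hand offers a reason for these small steps.

Still open, on these data alone, is whether a different group on this ring, such as an amine, a carboxylic acid or a longer alkyl chain, would move the number beyond the scatter. Also open, as far as these compounds go, is whether a plain phenyl ring at this place would stand with these three compounds.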